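Trimming the tert-butyl group of compound 3

A few compounds are considered here, and "the series" means these few. Any claim that something is new, unique, unknown or untested is made for them only; others in the source may bear on it.

In a functional assay for inhibition, with Homo sapiens as the target (a lower number here means tighter binding, a higher number weaker binding), compound 3 `CC(C)(C)c1ccc(OC(C)(C)C2OCC(C/C=C\CCC(=O)O)C(c3cccnc3)O2)cc1` gives 1910 nM, the highest of the three numbers. Compound 2 `COc1ccc(OC(C)(C)C2OCC(C/C=C\CCC(=O)O)C(c3cccnc3)O2)cc1` gives 302 nM, and compound 1 `Cc1ccc(C#N)c(OC(C)(C)C2OCC(C/C=C\CCC(=O)O)C(c3cccnc3)O2)c1` gives 15.9 nM. Compound 4 `Cc1ccc(OC(C)(C)C2OCC(C/C=C\CCC(=O)O)C(c3cccnc3)O2)cc1` has methyl in place of tert-butyl on an aromatic carbon. The closest evidence is a 6.3-fold higher number from compound 2 to compound 3 (0.80 log units; beyond the scatter), a change at the same place. The larger steps, a 19-fold higher number from compound 1 to compound 2 (1.28 log units; beyond the scatter) and a 120-fold higher number from compound 1 to compound 3 (2.08 log units; beyond the scatter), replace 2-cyano-5-methylphenyl and bear on it less directly. A modest move to a lower number in this assay is therefore expected, beyond the scatter. The expected step is a 4.2-fold lower number from compound 3 to compound 4 (0.63 log units; beyond the scatter). Compound 4 is estimated at 450 nM, with an expected range of 170 nM to 1200 nM.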

Compound 4, dissociation constant: 631 nM
The estimate for compound 4 lay 1.4-fold (0.15 log units) below the measured number; the measured number falls inside the stated range.
By their numbers in this assay, from the lowest: compound 1; then compound 2; then compound 4; then compound 3.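

In this assay, cutting tert-butyl down to methyl on this aromatic carbon gives a 3.0-fold lower number from compound 3 to compound 4 (0.48 log units; beyond the scatter), so the smaller group recovers part of the loss. Methoxy still holds the lowest number of the three groups at this place, with a 2.1-fold higher number from compound 2 to compound 4 (0.32 log units; beyond the scatter). Methyl does not close the gap to the 2-cyano-5-methylphenyl group, as a 40-fold higher number from compound 1 to compound 4 (1.60 log units; beyond the scatter) shows.

Going by these compounds, how an amine or a chlorine on this carbon would compare remains open. Nothing shown here explains these steps.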